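What added methyl groups may do to cell tolerance

The compounds below may be only part of what the source reports. "The series", "measured", "known", "first", "only" and "open" are said of these compounds alone.

In an ADME assay on MT4 cells (Homo sapiens) for cytotoxicity, read by MTT assay, with a stated time of 4 days (a higher number here means that more compound is tolerated, a lower number that less compound is tolerated), compound 1 `Cc1ccc(OCCn2ccc(=O)n(Cc3ccccc3)c2=O)cc1` gives 187000 nM. Compound 2 `O=c1ccn(CCOc2ccc(-c3ccccc3)cc2)c(=O)n1Cc1ccccc1` gives 31000 nM. Phenyl in place of methyl on an aromatic carbon thus produces a 6.0-fold lower number from compound 1 to compound 2 (0.78 log units; beyond the scatter).

Compound 3 `Cc1ccc(OCCn2ccc(=O)n(Cc3cccc(C)c3)c2=O)cc1` reports >= 38000 nM, which is a limit and not a number. Methyl in place of hydrogen on an aromatic carbon therefore gives a step that the limit leaves unreadable from compound 1 to compound 3, and compound 3 has no exact place among the others.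

Compound 4 `Cc1ccc(OCCn2ccc(=O)n(Cc3c(C)cc(C)cc3C)c2=O)cc1` is still unmeasured. It differs from compound 3 by 2,4,6-trimethylphenyl in place of 3-methylphenyl on a saturated chain carbon bound to an aromatic nitrogen. The closest guide is the unreadable methyl step, while the phenyl step is the only one with a known size, and it was modest and downward. Neither step matches this change exactly, so only a small shift is expected. The expected change in this assay is an at least 1.0-fold lower number from compound 3 to compound 4 (0.03 log units; that floor lies within the scatter), with no step beyond the scatter anticipated. For compound 4, the estimated value is 35000 nM, with an expected range of 12000 nM to 110000 nM.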

Compound 4, half-maximal cytotoxic concentration: 133000 nM
Compound 4: middle estimate off by 3.8-fold (0.58 log units), on the low side, and the stated range ends below it.
By their numbers in this assay, from the lowest: compound 2; then compounds 4 and 1 (each within the scatter of the next).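

In this assay, putting 2,4,6-trimethylphenyl in place of phenyl on a saturated chain carbon bound to an aromatic nitrogen gives a 1.4-fold lower number from compound 1 to compound 4 (0.15 log units; within the scatter), so compound 1 and compound 4 cannot be told apart. Within the data shown here, this is the first readable step at this place, and it shows that the methyl groups of 2,4,6-trimethylphenyl leave the tolerated concentration within the scatter. Compound 3 is recorded only as a limit and not as a number, so the steps to and from it cannot be read: the limit of >= 38000 nM in this assay, at which 1 of the 4 values shown sits.

On these data alone, what a single methyl group does on this ring therefore remains unknown. Also open, as far as these compounds go, is whether a group of another kind on the same ring, such as an amine or a carboxylic acid, would leave the number as undisturbed as these methyl groups do.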